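Compound 4: methylsulfonyl in place of methylcarbamoyl

The source may report more compounds than this note shows. Statements on the series, on what has been measured and on what is new or still open speak of the compounds shown alone.

In an ADME assay on microsomes from liver (Homo sapiens) for metabolic stability (a lower number here means that the compound disappears faster, a higher number that the compound lasts longer), compound 3 `CNC(=O)c1ccc(-c2nc(COc3cc(OC)cc4oc(-c5cn6nc(OC)sc6n5)cc34)cs2)cc1` gives 0.983 h, within the scatter of compound 2 `COc1cc(OCc2cccc(-c3cnc(OC)cn3)c2)c2cc(-c3cn4nc(OC)sc4n3)oc2c1` at 1.48 h. Compound 1 `COc1cc(OCc2csc(-c3ccc(C(F)(F)F)cc3)n2)c2cc(-c3cn4nc(OC)sc4n3)oc2c1` stands at > 2 h, which is a limit of the assay and not a number. Compound 4 `COc1cc(OCc2csc(-c3ccc(S(C)(=O)=O)cc3)n2)c2cc(-c3cn4nc(OC)sc4n3)oc2c1` carries methylsulfonyl in place of methylcarbamoyl on an aromatic carbon, para to a large group (methylsulfonyl in place of methylcarbamoyl on an aromatic carbon). Within the data shown here, the only measured step at this place is an at least 2.0-fold lower number from compound 1 to compound 3 (0.30 log units; that floor lies within the scatter), and it rests on (the limit of > 2 h in this assay, at which 1 of the 3 values shown sits). That step gives no firm size for the new change, so nothing beyond the scatter is expected. The expected change is a 1.3-fold higher number from compound 3 to compound 4 (0.12 log units; within the scatter). In this assay, the estimated half-life of compound 4 is 1.3 h, with an expected range of 0.65 h to 2.5 h.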

Compound 4, half-life: 1.22 h
Compound 4: the middle estimate sits 1.1-fold (0.03 log units) above what was measured, and the stated range covers the measured number.
By their numbers in this assay, from the lowest: compounds 3, 4 and 2 (each within the scatter of the next). At a limit, above all of these: compound 1.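

In this assay the swap shows a 1.2-fold higher number from compound 3 to compound 4 (0.09 log units; within the scatter) as methylsulfonyl replaces methylcarbamoyl on this aromatic carbon, so the hydrogen-bond donor of methylcarbamoyl can go without a change beyond the scatter. Against trifluoromethyl the comparison gives an at least 1.6-fold lower number from compound 1 to compound 4 (0.21 log units; that floor lies within the scatter) and no firm size, because compound 1 sits at a limit of the assay: the limit of > 2 h in this assay, at which 1 of the 4 values shown sits.

As far as these compounds go, whether compound 1 truly differs from compound 3 or compound 4 by more than the scatter stays open. Also open, from the compounds shown here alone, is how an amine or a carboxylic acid on this aromatic carbon would behave.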